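The compounds below may be only part of what the source reports. "The series", "measured", "known", "first", "only" and "open" are said of these compounds alone.

Compound 2 `O=C1c2ccccc2C(=O)N1CS` was tested in a functional assay on MCF7 cells (Homo sapiens) for cytotoxicity, read by MTT assay, with a stated time of 72 h; on this read-out lower numbers stand for stronger inhibition of growth and higher numbers for weaker inhibition of growth. In this assay compound 2 gives > 100000 nM, which is a limit of the assay rather than a number. Compound 1 `CSc1ccnc(SC)n1` was measured as well; in this assay compound 1 gives > 100000 nM, also a limit. Compound 2 thus stands at the limit of > 100000 nM in this assay, at which 2 of the 2 values shown sit. Compound 3 `N#CSCN1C(=O)c2ccccc2C1=O` differs from compound 2 by cyano in place of hydrogen on a sulfur. Within the data shown here, no measured step shows what such a change does here. The step of a number no higher from compound 2 to compound 3 (the limit leaves the size open) is expected to be none beyond the scatter. Compound 3 is therefore estimated at 100000 nM, within a range from 20000 nM to 300000 nM.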

Compound 3, concentration for 50% growth inhibition: 48100 nM
Estimate against measurement, compound 3: 2.1-fold (0.32 log units) above; measured number inside the range.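

In this assay, cyano in place of hydrogen on a sulfur brings an at least 2.0-fold lower number from compound 2 to compound 3 (0.31 log units; beyond the scatter), the first value among the compounds shown that is a number and not a limit. This shows that a change on this sulfur can strengthen growth inhibition, which the earlier limits alone could not show. The true size of the step stays unknown because compound 2 has only a limit: the limit of > 100000 nM in this assay, at which 2 of the 3 values shown sit.

On these data alone, whether a longer chain or an acetyl group on this sulfur would give a lower or higher number than cyano remains open.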